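Chloro for fluoro on the para carbon: expected cytotoxicity

This account rests on a few compounds, and the source may have more. Where it says the series, first, only, none or still open, it means among the compounds named here.

Measured compounds:
compound 1, `Fc1ccccc1/C=N/c1sc2c(c1-c1nc3ccccc3s1)CCC2`, 355 ug/mL
compound 2, `Clc1ccccc1/C=N/c1sc2c(c1-c1nc3ccccc3s1)CCC2`, 138 ug/mL
compound 3, `Fc1ccc(/C=N/c2sc3c(c2-c2nc4ccccc4s2)CCCC3)cc1`, 277 ug/mL

All three values come from an ADME assay on HeLa cells (Homo sapiens) for cytotoxicity, read by MTT assay, with a stated time of 72 h; a lower number here means that less compound is tolerated, a higher number that more compound is tolerated. Compound 4, `Clc1ccc(/C=N/c2sc3c(c2-c2nc4ccccc4s2)CCCC3)cc1`, is not yet measured there. The difference between the core of compound 1 and the core of compound 3 is not broken down here. Compound 2 differs from compound 1 by chloro in place of fluoro on an aromatic carbon, and that change gave a 2.6-fold lower number from compound 1 to compound 2 (0.41 log units; beyond the scatter). Compound 4 differs from compound 3 by chloro in place of fluoro on an aromatic carbon, the same kind of change, but the place differs: in compound 1 the carbon is ortho to a large group, in compound 3 it is para to a large group. Resting on that one earlier step, a step of similar direction is expected, a 1.8-fold lower number from compound 3 to compound 4 (0.27 log units; within the scatter), though it comes from a single pair and a different place. Compound 4 is therefore estimated at 150 ug/mL in this assay, with a range from 80 ug/mL to 300 ug/mL.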

Compound 4, half-maximal cytotoxic concentration: 431 ug/mL
Compound 4: middle estimate off by 2.9-fold (0.46 log units), on the low side, and the stated range ends below it.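

In this assay, chloro in place of fluoro gave a 1.6-fold higher number from compound 3 to compound 4 (0.19 log units; within the scatter) and leaves compound 3 and compound 4 not told apart. The change therefore did not carry over as one fixed step from one core to the other: the same change on two cores in this assay, a 2.6-fold lower number (0.41 log units; beyond the scatter) from compound 1 to compound 2 and a 1.6-fold higher number (0.19 log units; within the scatter) from compound 3 to compound 4, 4.0-fold (0.60 log units) apart, beyond the scatter of two such steps. Among these compounds, with only two pairs, which differ both in the core and in the place of the change, this does not show whether the core, the place or both set the size of the step.

Still open, on these data alone, is how this change behaves when only the core or only the place differs. Also open, as far as these compounds go, is what a methyl, a methoxy or an amine on that aromatic carbon would give.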